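Removing the propyl group: what to expect for compound 4

The source may hold more compounds than are shown below. What is called first, only, known or untested is meant among the compounds shown, and "the series" means these compounds.

Of the compounds shown here, three have been measured in a functional assay on DU-145 cells (Homo sapiens) for inhibition, read by trypan blue exclusion, with a stated time of 72 h; on this read-out higher numbers stand for weaker inhibition and lower numbers for stronger inhibition. Compound 1 `Cn1c(=O)c(S(=O)(=O)c2ccc(F)cc2)cc2cnc(Nc3cccc4[nH]ccc34)nc21` gives 750 nM. Compound 2 `Cn1c(=O)c(S(=O)(=O)Nc2ccc(F)cc2F)cc2cnc(Nc3ccc4[nH]ccc4c3)nc21` gives 5000 nM. Compound 3 `CCCn1c(=O)c(S(=O)(=O)c2ccc(F)cc2F)cc2cnc(Nc3ccc4[nH]ccc4c3)nc21` gives 1000 nM. Among these three numbers compound 3 holds the second highest. Its nearest neighbour is compound 1, and the two values lie within the usual scatter of repeated measurements, so no order between them can be read. Its furthest neighbour is compound 2, and that gap does lie beyond the scatter.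

Compound 4 `O=c1[nH]c2nc(Nc3ccc4[nH]ccc4c3)ncc2cc1S(=O)(=O)c1ccc(F)cc1F` has not yet been measured. The change from compound 3 to compound 4 is hydrogen in place of propyl on an aromatic nitrogen. Among the compounds with values here, no pair of measured compounds differs in only this one place, so the numbers in hand give no direct guide to the size of such a step. The expected step is a 1.5-fold higher number from compound 3 to compound 4 (0.18 log units; within the scatter), small enough to sit within the usual scatter, leaning toward weaker inhibition. Compound 4 is expected to give about 1500 nM, with a range from 500 nM to 4500 nM.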

Compound 4, half-maximal inhibitory concentration: 15000 nM
Compound 4: middle estimate off by 10-fold (1.00 log units), on the low side; the measured number lies above the stated range.
By their numbers in this assay, from the lowest: compounds 1 and 3 (each within the scatter of the next); then compound 2; then compound 4.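

Replacing the propyl group on this aromatic nitrogen with hydrogen gives a 15-fold higher number from compound 3 to compound 4 (1.18 log units; beyond the scatter) in this assay, a large move toward weaker inhibition. Within the data shown here, this is the first direct look at this position, and it shows that in this pair the group on the nitrogen matters a great deal: the propyl group cannot be removed without a clear loss. No measurement at hand explains why the step is so large.

Going by these compounds, what remains open is how inhibition changes with other groups on this nitrogen, such as an ethyl group, a butyl chain or a chain ending in an amine. Compound 1 and compound 2 carry a methyl group there but also differ from compound 3 elsewhere, so their steps cannot be read.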